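This account rests on a few compounds, and the source may have more. Where it says the series, first, only, none or still open, it means among the compounds named here.

Three compounds share one core and differ only in a single group on an aromatic carbon. Compound 1 `N#Cc1cncc(OC[C@@H]2CCN2)c1` carries a cyano group, and in an assay on brain for binding affinity to Neuronal acetylcholine receptor; alpha4/beta2 (Rattus norvegicus), read by radioligand binding (on this read-out higher numbers stand for weaker inhibition and lower numbers for stronger inhibition), compound 1 gives 0.025 nM. Compound 2 `CCOc1cncc(OC[C@@H]2CCN2)c1` carries an ethoxy group, and in this assay compound 2 gives 0.039 nM; the step of a 1.6-fold higher number from compound 1 to compound 2 (0.19 log units; within the scatter) is within the scatter. Compound 3 `NCc1cncc(OC[C@@H]2CCN2)c1` carries an aminomethyl group, and in this assay compound 3 gives 4.4 nM, the highest of the three numbers: the steps of a 180-fold higher number from compound 1 to compound 3 (2.25 log units; beyond the scatter) and a 110-fold higher number from compound 2 to compound 3 (2.05 log units; beyond the scatter) are both large and beyond the scatter.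

Compound 4 `CC(=O)NCc1cncc(OC[C@@H]2CCN2)c1` has not yet been measured. It differs from compound 3 by acetyl in place of hydrogen on an amine nitrogen, so that the free amine becomes an acetamido group. Going by the values given here, no measured step touches this nitrogen directly; the steps that bear on it are the two large ones, which show how far the free aminomethyl group lies above the cyano and ethoxy groups of compound 1 and compound 2. Because a 180-fold higher number from compound 1 to compound 3 (2.25 log units; beyond the scatter) and a 110-fold higher number from compound 2 to compound 3 (2.05 log units; beyond the scatter) are both large, and the acetyl removes the free amine that sets compound 3 apart, a return towards lower numbers is expected, though its size is uncertain. The expected step is a 7.3-fold lower number from compound 3 to compound 4 (0.87 log units; beyond the scatter). Compound 4 is therefore estimated at 0.6 nM in this assay, with a range from 0.08 nM to 5 nM.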

Compound 4, inhibition constant: 0.54 nM
Compound 4: middle estimate off by 1.1-fold (0.05 log units), on the high side, within the range that was stated.
By their numbers in this assay, from the lowest: compounds 1 and 2 (each within the scatter of the next); then compound 4; then compound 3.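

In this assay the step of an 8.1-fold lower number from compound 3 to compound 4 (0.91 log units; beyond the scatter) shows that the high number of the aminomethyl compound can be changed at the amine nitrogen alone, with the same saturated chain carbon still attached to the aromatic carbon. The recovery is only partial: the acetamidomethyl group still leaves a 14-fold higher number from compound 2 to compound 4 (1.14 log units; beyond the scatter) and a 22-fold higher number from compound 1 to compound 4 (1.33 log units; beyond the scatter), so compound 4 falls short of the ethoxy and cyano compounds while remaining clearly below compound 3. Nothing available here explains why acetyl on this nitrogen has this effect, so the step stands as an observation without a known cause.

The compounds shown leave open whether this gain belongs to the acetyl group itself or would also follow from other groups on the same nitrogen, such as a methyl group, a methanesulfonyl group or a longer acyl chain. They also leave open how a carboxylic acid, or an amine carried on a longer chain, would behave on this aromatic carbon of the shared core.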